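Aryl variation at the cyano-flanked position: cytotoxicity notes

The source may report more compounds than this note shows. Statements on the series, on what has been measured and on what is new or still open speak of the compounds shown alone.

Measured compounds:
compound 1 `CSc1nc(NCCCCNc2ccnc3cc(Cl)ccc23)c(C#N)c(-c2cccc([N+](=O)[O-])c2)n1`: 20000 nM
compound 2 `COc1cc(-c2nc(SC)nc(NCCCCNc3ccnc4cc(Cl)ccc34)c2C#N)cc(OC)c1OC`: 4000 nM

In an ADME assay on Vero cells (Chlorocebus sabaeus) for cytotoxicity, read by microscopy (on this read-out lower numbers stand for higher toxicity in this test and higher numbers for lower toxicity in this test), compound 2 gives the lowest of the two numbers recorded; compound 1 gives 20000 nM, and the step of a 5.0-fold lower number from compound 1 to compound 2 (0.70 log units; beyond the scatter) lies beyond the scatter. Compound 3 `CSc1nc(NCCCCNc2ccnc3cc(Cl)ccc23)c(C#N)c(-c2ccc(C)cc2)n1` is not yet measured; it differs from compound 2 as follows: 4-methylphenyl in place of 3,4,5-trimethoxyphenyl on an aromatic carbon. Within the data shown here, only the one measured step, from a nitro-bearing aryl to the trimethoxyphenyl, bears on this change; it was modest in size and concerned a different pair of aryl groups, so it gives no direct guide to a 4-methylphenyl. With compound 2 at the low end of the pair and compound 1 higher, the expectation is that compound 3 moves back toward compound 1, giving a 2.5-fold higher number from compound 2 to compound 3 (0.40 log units; beyond the scatter), with wide uncertainty. The estimate for compound 3 in this assay is 10000 nM, expected to fall between 3000 nM and 30000 nM.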

Compound 3, minimum cytotoxic concentration: 20000 nM
Compound 3: the middle estimate sits 2.0-fold (0.30 log units) below what was measured; measured number inside the range.
By their numbers in this assay, from the lowest: compound 2; then compounds 1 and 3 (each within the scatter of the next).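

In this assay, 4-methylphenyl in place of 3,4,5-trimethoxyphenyl on the aromatic carbon ortho to the cyano group gives a 5.0-fold higher number from compound 2 to compound 3 (0.70 log units; beyond the scatter), while 4-methylphenyl in place of 3-nitrophenyl gives no change at the digits printed from compound 1 to compound 3 (within the scatter). At this position, the lower number therefore goes with the 3,4,5-trimethoxyphenyl of compound 2 in this set, and two quite different aryl groups, in compound 1 and compound 3, read alike. No measurement at hand bears on the reason for this difference.

Open, from the compounds shown here alone, is whether one methoxy group, as in 4-methoxyphenyl, is enough to give a number like that of compound 2, or whether all three are needed. Also open, going by these compounds, is how an unsubstituted phenyl or a dimethylamino-bearing phenyl would read at this position.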